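The compounds below may be only part of what the source reports. "The series", "measured", "known", "first", "only" and "open" are said of these compounds alone.

Measured so far:
- compound 1 `CC(C)n1c(/C=C2/C(=O)Nc3ccc(F)cc32)nc2ccccc21` gives 24500 nM
- compound 2 `CCn1c(/C=C2/C(=O)Nc3ccc(C)cc32)nc2ccccc21` gives 39300 nM
- compound 3 `Cn1c(/C=C2/C(=O)Nc3ccc([N+](=O)[O-])cc32)nc2ccccc21` gives > 50000 nM (a limit)

All three values come from a functional assay on DU-145 cells (Homo sapiens) for cytotoxicity, read by MTT assay, with a stated time of 48 h (a higher number here means a weaker inhibitor, a lower number a stronger inhibitor), and are read as half-maximal inhibitory concentrations. Compound 1 and compound 2 lie within the usual scatter of each other. Compound 3 has no number and stands at the limit of > 50000 nM in this assay, at which 1 of the 3 values shown sits, which is a limit of the assay.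

Compound 4 `Cn1c(/C=C2/C(=O)Nc3ccc(F)cc32)nc2ccccc21` differs from compound 3 as follows: fluoro in place of nitro on an aromatic carbon. In words, this is fluoro in place of nitro on an aromatic carbon.

For the measured compounds named here, no measured step isolates this change, so the expectation rests on the values at hand. Compound 1 also carries fluoro and gives 24500 nM in this assay, although its core differs elsewhere from that of compound 4. A modest move toward stronger inhibition is therefore expected, possibly not much beyond the scatter.

The estimated step is an at least 1.6-fold lower number from compound 3 to compound 4 (0.22 log units; that floor lies within the scatter) and remains loose, since its starting point is only a limit.

For compound 4 the expected value is 30000 nM, with an estimated range from 13000 nM to 50000 nM in this read-out.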

Compound 4, half-maximal inhibitory concentration: 32300 nM
Compound 4: the middle estimate sits 1.1-fold (0.03 log units) below what was measured; the range from low to high includes it.
By their numbers in this assay, from the lowest: compounds 1, 4 and 2 (each within the scatter of the next). At a limit, above all of these: compound 3.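

Fluoro in place of nitro on this aromatic carbon turns a limit into a number in this assay (an at least 1.5-fold lower number from compound 3 to compound 4 (0.18 log units; that floor lies within the scatter)). The size of this step remains a floor, since compound 3 has only a limit of the assay and no number: the limit of > 50000 nM in this assay, at which 1 of the 4 values shown sits.

With fluoro held on the same carbon, methyl in place of isopropyl on the aromatic nitrogen leaves compound 4 within the scatter of compound 1 (a 1.3-fold higher number from compound 1 to compound 4 (0.12 log units; within the scatter)), so this change to the nitrogen group shows no resolved effect here.

From the compounds shown here alone, how far the step from nitro to fluoro extends beyond its floor stays open, as does whether the nitrogen group matters with anything other than fluoro on the aromatic carbon. Also open, going by these compounds, is how an amine or a carboxylic acid on this carbon, or a longer chain on the aromatic nitrogen, would read in this assay.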